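The source may hold more compounds than are shown below. What is called first, only, known or untested is meant among the compounds shown, and "the series" means these compounds.

- Compound 1 `CSc1ccc(C2=C(c3ccc(F)c(C)c3)C(=O)N3CCCC3C2)cc1`: 500 nM
- Compound 2 `CSc1ccc(C2=C(c3ccc(OCC4CO4)cc3)C(=O)N3CCCC3C2)cc1`: 30 nM

In a functional assay on NCI-H520 cells (Homo sapiens) for cytotoxicity (on this read-out higher numbers stand for weaker inhibition of growth and lower numbers for stronger inhibition of growth), compound 2 has the lower of the two numbers, and its gap to compound 1 lies beyond the usual scatter. Compound 3 `CSc1ccc(C2=C(c3ccc(Br)cc3)C(=O)N3CCCC3C2)cc1` keeps the shared core but has bromo in place of (oxiran-2-yl)methoxy on an aromatic carbon. Within the data shown here, no measured pair shows this exact change. Compound 1 also lacks (oxiran-2-yl)methoxy and gives 500 nM, so weaker growth inhibition is expected, with a step beyond the scatter. The expected change is a 6.7-fold higher number from compound 2 to compound 3 (0.82 log units; beyond the scatter). For compound 3, the estimated value is 200 nM, with a range of 60 nM to 700 nM.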

Compound 3, concentration for 50% growth inhibition: 7000 nM
Estimate against measurement, compound 3: 35-fold (1.54 log units) below, and the stated range ends below it.
By their numbers in this assay, from the lowest: compound 2; then compound 1; then compound 3.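

In this assay, bromo in place of (oxiran-2-yl)methoxy at this para position gives a 230-fold higher number from compound 2 to compound 3 (2.37 log units; beyond the scatter), so this exchange costs far more than compound 1 alone suggested. Without (oxiran-2-yl)methoxy the aryl group still matters: 4-bromophenyl in place of 4-fluoro-3-methylphenyl gives a 14-fold higher number from compound 1 to compound 3 (1.15 log units; beyond the scatter). Nothing available here explains either step.

The compounds shown leave open whether the three-membered ring itself is needed, or whether a plain methoxy or a longer ether chain at this position would keep the growth inhibition of compound 2.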